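This account rests on a few compounds, and the source may have more. Where it says the series, first, only, none or still open, it means among the compounds named here.

Measured so far in a functional assay on PC-12 cells (Rattus norvegicus) for cytotoxicity, read by MTT assay, with stated times of 2 h and 24 h, tested at 10 uM; on this read-out lower numbers stand for a weaker effect and higher numbers for a stronger effect at the one concentration tested:
- compound 1 `CCc1ccc(-n2nc(-c3ccc(C(F)(F)F)cc3O)nc2-c2ccccc2O)cc1`: 107%
- compound 2 `N#Cc1ccc(-n2nc(-c3ccc(C(F)(F)F)cc3O)nc2-c2ccccc2O)cc1`: 98.9%

Among the measured compounds shown here, on these two numbers compound 2 and compound 1 lie within the scatter of each other, so neither stands apart from the other in this assay; the single measured step, a number 8.1 percentage points lower from compound 1 to compound 2 (within the scatter), changes only the group on the aromatic carbon of the ring attached to the aromatic nitrogen and is itself within the scatter.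

Compound 3 `Oc1cc(C(F)(F)F)ccc1-c1nc(-c2ccccc2O)n(-c2ccccc2C(F)(F)F)n1` differs from compound 2 by 2-(trifluoromethyl)phenyl in place of 4-cyanophenyl on an aromatic nitrogen. For the measured compounds named here, the one step that bears on this, a number 8.1 percentage points lower from compound 1 to compound 2 (within the scatter), touched the same ring and left the read-out within the scatter, which is thin ground: it does not cover the change of the whole ring substituent, and no measured pair shows a trifluoromethyl group on that ring. With nothing in the measured steps pointing either way, the expected step for compound 3 is a number 1.1 percentage points higher from compound 2 to compound 3 (within the scatter), that is none beyond the scatter. Compound 3 is therefore estimated at 100% in this assay, with a range from 85% to 115%.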

Compound 3, a percentage reported as activity, at one concentration (the size of the read-out at that concentration, not a potency): 92.2%
Beside the measured number, compound 3's estimate is 7.8 percentage points above it; the range from low to high includes it.
By their numbers in this assay, from the lowest: compounds 3, 2 and 1 (each within the scatter of the next, the first and the last beyond it).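

In this assay, the replacement of the whole ring substituent on the aromatic nitrogen gives two different outcomes: 2-(trifluoromethyl)phenyl in place of 4-cyanophenyl gives a number 6.7 percentage points lower from compound 2 to compound 3 (within the scatter), while the same group in place of 4-ethylphenyl gives a number 14.8 percentage points lower from compound 1 to compound 3 (beyond the scatter). Among the compounds shown here, this is the first step at this position to pass the scatter, so the read-out can respond to the group here, though only modestly and only in the comparison with 4-ethylphenyl, since compound 2 stays within the scatter of both compound 1 and compound 3. No measurement at hand accounts for this step.

On these data alone, it remains open what a plain phenyl, a 4-(trifluoromethyl)phenyl or a 4-aminophenyl group would give on the aromatic nitrogen, and so whether the step follows the trifluoromethyl group itself or its place on the ring. The rest of the shared core is the same in all three compounds, so these numbers say nothing about changes there, such as an amine or a methoxy group in place of either hydroxyl.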